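A urea with sulfamoylaminophenyl in place of trifluoromethylphenyl

The compounds below may be only part of what the source reports. "The series", "measured", "known", "first", "only" and "open" are said of these compounds alone.

Compound 2 `O=C(Nc1cccc(-c2nc(-c3ccc(NC(=O)c4cccnc4)cc3Cl)no2)c1)Nc1cccc(C(F)(F)F)c1` is tested in a functional assay on MDA-MB-231 cells (Homo sapiens) for antiproliferative activity, read by MTT assay, with a stated time of 72 h (on this read-out higher numbers stand for weaker inhibition and lower numbers for stronger inhibition), where compound 2 gives 1900 nM. Compound 3 `O=C(Nc1cccc(-c2nc(-c3ccc(NC(=O)c4cccnc4)cc3Cl)no2)c1)Nc1cc(C(F)(F)F)cc(C(F)(F)F)c1` gives 1900 nM in this assay, and the step of no change at the digits printed from compound 2 to compound 3 (within the scatter) shows that adding a second trifluoromethyl leaves the read-out where it was. Compound 1 `COc1cccc(S(=O)(=O)Nc2cccc(-c3nc(-c4ccc(NC(=O)c5cccnc5)cc4Cl)no3)c2)c1` reaches only the limit > 10000 nM in this assay. That value is a limit, not a number, as the limit of > 10000 nM in this assay, at which 1 of the 3 values shown sits, records. For the measured compounds named here, compound 2 therefore stands level with compound 3, and the one further value shown is a limit.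

Compound 4 `NS(=O)(=O)Nc1ccc(NC(=O)Nc2cccc(-c3nc(-c4ccc(NC(=O)c5cccnc5)cc4Cl)no3)c2)cc1` differs from compound 2 by 4-(sulfamoylamino)phenyl in place of 3-(trifluoromethyl)phenyl on an amide-type nitrogen. Going by the values given here, no measured step covers this exchange: the one step with a number, no change at the digits printed from compound 2 to compound 3 (within the scatter), alters the same aryl group and stays within the scatter, and compound 1 is known only as a limit. The expected step of a 1.6-fold higher number from compound 2 to compound 4 (0.20 log units; within the scatter) is accordingly modest, with the wider uncertainty leaning toward weaker inhibition. Compound 4 is estimated at 3000 nM, within a range of 800 nM to 12000 nM.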

Compound 4, half-maximal inhibitory concentration: 8900 nM
Compound 4: middle estimate off by 3.0-fold (0.47 log units), on the low side; the range from low to high includes it.
By their numbers in this assay, from the lowest: compounds 2 and 3 (each within the scatter of the next); then compound 4. At a limit, above all of these: compound 1.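

In this assay, 4-(sulfamoylamino)phenyl in place of 3-(trifluoromethyl)phenyl on the amide-type nitrogen gives a 4.7-fold higher number from compound 2 to compound 4 (0.67 log units; beyond the scatter). For the compounds shown here, this is the first step at this place that lies beyond the scatter, so the aryl group on this nitrogen can change the read-out, which the second trifluoromethyl of compound 3 did not show. Nothing in the data shown bears on why the number rises with this exchange.

From the compounds shown here alone, whether the step belongs to the sulfamoylamino group itself or to the loss of trifluoromethyl stays open, as the two change together. Going by these compounds, how a plain amine or a carboxylic acid on this phenyl ring would read in this assay also remains open.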